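Dropping one chloro from a dichloropurine: what cytotoxicity follows

A few compounds are considered here, and "the series" means these few. Any claim that something is new, unique, unknown or untested is made for them only; others in the source may bear on it.

Measured compounds:
compound 1 `ClCc1cccc(Cn2cnc3c(Cl)nc(Cl)nc32)c1` — 2340 nM
compound 2 `Nc1nc(Cl)c2ncn(Cc3ccccc3CCl)c2n1` — 4790 nM
compound 3 `ClCc1ccccc1Cn1cnc2nc(Cl)nc(Cl)c21` — 350 nM

Three compounds that share a purine-type core carrying a chloromethylbenzyl group have been tested in a functional assay on SK-MEL-28 cells (Homo sapiens) for cytotoxicity, read by sulforhodamine B assay, with a stated time of 48 h; a lower number here means a stronger inhibitor of growth, a higher number a weaker inhibitor of growth. Compound 1 `ClCc1cccc(Cn2cnc3c(Cl)nc(Cl)nc32)c1` gives 2340 nM in this assay, which is the second highest of the three numbers. Its nearest neighbour is compound 2 `Nc1nc(Cl)c2ncn(Cc3ccccc3CCl)c2n1`, whose value of 4790 nM lies beyond the scatter from that of compound 1. The furthest is compound 3 `ClCc1ccccc1Cn1cnc2nc(Cl)nc(Cl)c21`, whose value of 350 nM is well below that of compound 1. Each of these pairs differs in more than one place at once. Among the compounds with values here, no single-change step between them can be read off.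

The next compound, compound 4 `ClCc1cccc(Cn2cnc3c(Cl)ncnc32)c1`, differs from compound 1 in one place only: hydrogen in place of chloro on an aromatic carbon.

Within the data shown here, no measured pair reports this exact change, so the expectation for compound 4 rests on the spread of the three values. The chloro that leaves is a small group, and the remaining chloro and the chloromethylbenzyl stay in place; a modest weakening is expected, with an estimated step from compound 1 to compound 4 of a 1.5-fold higher number from compound 1 to compound 4 (0.17 log units; within the scatter) in this assay. Compound 4 is therefore expected to give about 3500 nM in this assay, within a range of 1200 nM to 10000 nM.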

Compound 4, concentration for 50% growth inhibition: 2230 nM
The estimate for compound 4 lay 1.6-fold (0.20 log units) above the measured number; low and high end bracket the measured number.
By their numbers in this assay, from the lowest: compound 3; then compounds 4 and 1 (each within the scatter of the next); then compound 2.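

Within the data shown here, the first single-change step in this set shows that, in this assay, replacing chloro with hydrogen on the aromatic carbon between two ring nitrogen atoms gives a 1.0-fold lower number from compound 1 to compound 4 (0.02 log units; within the scatter). At this position, then, the chloro can be absent with no difference from compound 1 that this read-out can distinguish from the usual scatter, with the other chloro and the chloromethylbenzyl group unchanged. No supporting measurement is available to explain why this exchange leaves the number within the scatter.

The compounds shown do not reveal whether a larger group at the same carbon, such as a methoxy group or a longer alkyl chain, would also leave the growth-inhibition number within the scatter, or whether the remaining chloro can be replaced in the same way. They also leave open whether the same exchange would give a comparable result on compound 3, whose chloromethylbenzyl group and remaining framework differ from those of compound 1 in more than one place.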